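Swapping the Amide Cap: Ester to Short Alkyl Chain

The source may hold more compounds than are shown below. What is called first, only, known or untested is meant among the compounds shown, and "the series" means these compounds.

Of the compounds shown here, three sharing one core have been tested in a functional assay on HUVEC cells (Homo sapiens) for inhibition, tested at 5 ug/mL; on this read-out higher numbers stand for a stronger effect at the one concentration tested and lower numbers for a weaker effect. Compound 1 `COc1cc(/C=C/C(=O)c2cccc(NC(=O)c3cc(Cl)cc(Cl)c3)c2)ccc1O` gives 51%, compound 2 `COc1cc(/C=C/C(=O)c2cccc(NC(=O)c3ccco3)c2)ccc1O` gives 82%, and compound 3 `COC(=O)C(=O)Nc1cccc(C(=O)/C=C/c2ccc(O)c(OC)c2)c1` gives 20%. Compound 3 stands lowest of the three: the change a number 31 percentage points lower from compound 1 to compound 3 (beyond the scatter) and the change a number 62 percentage points lower from compound 2 to compound 3 (beyond the scatter) both show that putting methoxycarbonyl on the carbonyl carbon lowered the number well beyond the scatter.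

Compound 4 `CCCC(=O)Nc1cccc(C(=O)/C=C/c2ccc(O)c(OC)c2)c1` differs from compound 3 by propyl in place of methoxycarbonyl on a carbonyl carbon. For the measured compounds named here, no measured step covers this particular swap; the two steps above only show that compound 3, the one compound carrying methoxycarbonyl, sits far below compounds 1 and 2, which carry ring groups. A propyl group is neither, so a rise in this assay is expected, but of uncertain size. Compound 4 is therefore estimated at 45%, with a range from 20% to 70%. This corresponds to an expected step of a number 25 percentage points higher from compound 3 to compound 4 (beyond the scatter).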

Compound 4, a percentage reported as inhibition, at one concentration (the size of the read-out at that concentration, not a potency): 57%
Beside the measured number, compound 4's estimate is 12 percentage points below it; measured number inside the range.
By their numbers in this assay, from the lowest: compound 3; then compounds 1 and 4 (each within the scatter of the next); then compound 2.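

In this assay, replacing methoxycarbonyl with propyl gives a number 37 percentage points higher from compound 3 to compound 4 (beyond the scatter), so a ring on this carbonyl carbon is not required to move clear of the low number of compound 3. Ring groups do not all rank the same against the chain: the step of a number 6 percentage points higher from compound 1 to compound 4 (within the scatter) leaves propyl and 3,5-dichlorophenyl unresolved, whereas the step of a number 25 percentage points lower from compound 2 to compound 4 (beyond the scatter) shows furan-2-yl still ahead of propyl. No measurement available here gives a reason for these differences.

As far as these compounds go, whether a longer chain such as hexyl, or a branched one such as isopropyl, would raise or lower the number on this carbonyl carbon remains open. From the compounds shown here alone, the outcome with an amine or a carboxylic acid at the end of the chain is equally open, and these read-outs show only a stronger or weaker effect at the one concentration tested for all four compounds.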